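The source may report more compounds than this note shows. Statements on the series, on what has been measured and on what is new or still open speak of the compounds shown alone.

Of the compounds shown here, two of a shared core have been measured in a functional assay on the whole organism (strain Wistar) for inhibition, with Rattus norvegicus as the target, read by paw edema, with a stated time of 1 h, at a dose of 100 mg/kg; on this read-out lower numbers stand for less inhibition and higher numbers for more inhibition at the one dose given (going by the name of the read-out). Compound 1 `COc1cc2c(cc1OC)C(CC(=O)O)CC2` carries a free carboxylic acid and in this assay compound 1 gives 18.8%. Compound 2 `COc1cc2c(cc1OC)C(CC(=O)Nc1ccc(Br)cc1)CC2` turns that acid into an amide bearing a 4-bromophenyl group, and in this assay compound 2 gives 50%. Within the data shown here, the one step measured so far, a number 31.2 percentage points higher from compound 1 to compound 2 (beyond the scatter), is large. Compound 2 therefore holds the higher of the two numbers, with compound 1 below it by a gap beyond the scatter.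

Compound 3 `COc1ccccc1NC(=O)CC1CCc2cc(OC)c(OC)cc21` keeps the amide but changes the group on its nitrogen: 2-methoxyphenyl in place of 4-bromophenyl on an amide-type nitrogen. Among the measured compounds shown here, no measured step speaks to a swap of one aryl group for another on this nitrogen; the only step known, a number 31.2 percentage points higher from compound 1 to compound 2 (beyond the scatter), concerns the acid-to-amide change, which compound 3 shares with compound 2. The expectation is therefore that compound 3 stays near compound 2, with an estimated step of a number 8 percentage points lower from compound 2 to compound 3 (within the scatter) that lies within the scatter. In this assay compound 3 is estimated at 42%, expected between 25% and 60%.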

Compound 3, a percentage reported as inhibition, in the whole organism at one dose (the size of the read-out at that dose, not a potency): 28.1%
The estimate for compound 3 lay 13.9 percentage points above the measured number, within the range that was stated.
By their numbers in this assay, from the lowest: compounds 1 and 3 (each within the scatter of the next); then compound 2.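

In this assay, the result shows that the group on the amide-type nitrogen matters, not only the presence of the amide: putting 2-methoxyphenyl in place of 4-bromophenyl gives a number 21.9 percentage points lower from compound 2 to compound 3 (beyond the scatter) as a modest step. The large gain seen with compound 2 therefore does not carry over to every aryl amide of this core, as compound 3 at 28.1% and compound 1 at 18.8% lie within the scatter of each other. No measurement at hand offers an explanation for the step between the two aryl groups.

This swap changes both the atom on the ring, bromine against the oxygen of a methoxy group, and the number in the group's name, so the compounds shown cannot separate those two changes from each other. A 4-methoxyphenyl or a 2-bromophenyl group on the same nitrogen would pull them apart, and a plain phenyl group would show what the ring gives with neither bromine nor methoxy attached.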